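Pyridinyl for furanyl on the cap of compound 3

This account rests on a few compounds, and the source may have more. Where it says the series, first, only, none or still open, it means among the compounds named here.

Measured compounds:
compound 1 `CN(C)c1ccc(C(=O)N[C@@H](CCCCCC(=O)NO)C(=O)NCc2ccccc2)cc1`: 12000 nM
compound 2 `CN(C)c1ccc(C(=O)NC(CCCCCC(=O)NO)C(=O)NCc2ccccc2)cc1`: 870 nM
compound 3 `CC(C)CCNC(=O)C(CCCCCC(=O)NO)NC(=O)c1ccco1`: 4400 nM

All three were tested in a functional assay on NFF cells (Homo sapiens) for antiproliferative activity; on this read-out higher numbers stand for weaker inhibition and lower numbers for stronger inhibition. Compound 3 stands second highest of the three numbers; its nearest neighbour is compound 1 and its furthest is compound 2, and both gaps lie beyond the scatter.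

Compound 4 `CC(C)CCNC(=O)C(CCCCCC(=O)NO)NC(=O)c1cccnc1` differs from compound 3 in one place: pyridin-3-yl in place of furan-2-yl on a carbonyl carbon. Within the data shown here, the only measured step, a 14-fold lower number from compound 1 to compound 2 (1.14 log units; beyond the scatter), concerns a different place, namely (the fact that one of compounds 1 and 2 is drawn with a defined configuration and the other without, at the place where they differ), and does not bear on a change of the aryl group on the carbonyl carbon. Among the measured compounds shown here, no measured step therefore informs the change. For compound 4 the estimated step is a 1.1-fold lower number from compound 3 to compound 4 (0.04 log units; within the scatter), which is expected to stay within the scatter. Compound 4 is estimated at 4000 nM, with a range from 1300 nM to 12000 nM.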

Compound 4, half-maximal inhibitory concentration: 12000 nM
The estimate for compound 4 lay 3.0-fold (0.48 log units) below the measured number; the range from low to high includes it.
By their numbers in this assay, from the lowest: compound 2; then compound 3; then compounds 1 and 4 (each within the scatter of the next).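

In this assay, the cap on this carbonyl carbon proves sensitive to the aryl group: pyridin-3-yl in place of furan-2-yl gives a 2.7-fold higher number from compound 3 to compound 4 (0.44 log units; beyond the scatter), a step beyond the scatter. This happens although the counts of hydrogen-bond donors and acceptors stay the same, while a five-membered aromatic ring gives way to a six-membered one. Nothing available accounts for this step.

The compounds shown leave open whether ring size or the hetero atom matters here. A phenyl or thiophene cap on the same carbonyl carbon would separate the two.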